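Pyridin-3-yl in Place of Methyl on a Carbonyl Carbon

A few compounds are considered here, and "the series" means these few. Any claim that something is new, unique, unknown or untested is made for them only; others in the source may bear on it.

Measured so far:
compound 1, `Cc1nn(C(=O)c2ccncc2)c(N)c1-c1ccc(Cl)c(Cl)c1`, 58200 nM
compound 2, `CC(=O)n1nc(N)c(-c2ccc(Cl)c(Cl)c2)c1C`, > 100000 nM

In an assay on Sf9 cells for inhibition of mitogen-activated protein kinase kinase kinase 14 (Homo sapiens), read by ADP-Glo, with a stated time of 60 min (a higher number here means a weaker inhibitor, a lower number a stronger inhibitor), compound 1 gives 58200 nM. For compound 2 only a limit is known: in this assay compound 2 gives > 100000 nM, which is the limit of the measurement and not a number (the limit of > 100000 nM in this assay, at which 1 of the 2 values shown sits). Compound 3, `Cc1c(-c2ccc(Cl)c(Cl)c2)c(N)nn1C(=O)c1cccnc1`, differs from compound 2 by pyridin-3-yl in place of methyl on a carbonyl carbon, in words pyridin-3-yl in place of methyl on a carbonyl carbon. For the measured compounds named here, no step between two measured compounds is available, so the size of this change can only be guessed. The change is expected to strengthen inhibition somewhat, as an estimated step of an at least 1.6-fold lower number from compound 2 to compound 3 (0.22 log units; that floor lies within the scatter). Compound 3 is therefore estimated at 60000 nM, within 20000 nM to 200000 nM.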

Compound 3, half-maximal inhibitory concentration: > 100000 nM
Compound 3 gave a limit, no number; the forecaster's own chance of this, stated with the estimate: 40%; middle value at least 1.6-fold (0.22 log units) away from the limit.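

Compound 2 and compound 3 both give a limit and not a number, so no step between them can be read: the limit of > 100000 nM in this assay, at which 2 of the 3 values shown sit.

Going by these compounds, whether pyridin-3-yl in place of methyl on a carbonyl carbon changes inhibition at all stays open.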